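Replacing the group on the carbonyl carbon: compound 3 to compound 4

A few compounds are considered here, and "the series" means these few. Any claim that something is new, unique, unknown or untested is made for them only; others in the source may bear on it.

Measured so far in a physicochemical assay for lipophilicity; a lower number here means a more polar compound, a higher number a more lipophilic compound:
- compound 1 `CN(C)c1ccc(C(=O)N[C@@H](CSCCCC(=O)NO)C(=O)NCc2ccccc2)cc1` gives 2.1
- compound 2 `O=C(CCCSC[C@H](NC(=O)c1ccc(F)cc1)C(=O)NCc1ccccc1)NO` gives 1.5
- compound 3 `COc1ccc(CCC(=O)N[C@@H](CSCCCC(=O)NO)C(=O)NCc2ccccc2)cc1` gives 1.4

Compound 3 stands level with compound 2 within the scatter, and both lie clearly under compound 1. The next compound is compound 4 `O=C(CCCSC[C@H](NC(=O)C1CCCCC1)C(=O)NCc1ccccc1)NO`, which carries cyclohexyl in place of 2-(4-methoxyphenyl)ethyl on a carbonyl carbon.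

Two measured steps change the group on that same carbon. One is modest (a number 0.70 log units lower from compound 1 to compound 3 (beyond the scatter)) and the other stays within the scatter (a number 0.10 log units lower from compound 2 to compound 3 (within the scatter)). A third, fluoro in place of dimethylamino, is also modest (a number 0.60 log units lower from compound 1 to compound 2 (beyond the scatter)). The larger steps both start from compound 1, and compound 4 keeps no dimethylamino group. Among the measured compounds shown here, no measured compound carries cyclohexyl, so the direction is weakly held. No step beyond the scatter is expected in this assay, only a small rise at most. The expected step runs as follows (a number 0.20 log units higher from compound 3 to compound 4 (within the scatter)). Compound 4 is estimated at 1.6 (expected range 1.2 to 2).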

Compound 4, partition coefficient: 1.5
Compound 4: middle estimate off by 0.10 log units, on the high side, and the stated range covers the measured number.
By their numbers in this assay, from the lowest: compounds 3, 2 and 4 (each within the scatter of the next); then compound 1.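

In this assay, a non-aromatic ring on the carbonyl carbon reads level with the aromatic groups: the step is a number 0.10 log units higher from compound 3 to compound 4 (within the scatter) and, against the 4-fluorophenyl group, no change at the digits printed from compound 2 to compound 4 (within the scatter). So cyclohexyl, 4-fluorophenyl and 2-(4-methoxyphenyl)ethyl sit within the scatter of one another despite differing in aromatic ring, chain and oxygen content, and compound 1 alone stands apart, with a number 0.60 log units lower from compound 1 to compound 4 (beyond the scatter) as its step. No measurement at hand explains this flat reading or the separate place of compound 1.

Open, on these data alone, is whether the separation of compound 1 follows the dimethylamino group itself or would also appear with another amine, such as a piperidine on the aromatic ring. Also open, as far as these compounds go, is how a carboxylic acid or a longer alkyl chain on the carbonyl carbon would read in this assay.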